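The source may hold more compounds than are shown below. What is called first, only, known or untested is meant among the compounds shown, and "the series" means these compounds.

Measured compounds in a functional assay on HEK293 cells for agonist activity at D(4) dopamine receptor (Homo sapiens), read by FLIPR; a higher number here means that more compound is needed for the effect, a lower number that less compound is needed:
- compound 1, `Cc1cccc(NC(=O)CN2CCC(c3ccccc3C#N)CC2)c1`, compound 1 gives 8 nM
- compound 2, `CCc1cccc(C)c1NC(=O)CN1CCC(c2ccccn2)CC1`, compound 2 gives 111 nM
- compound 3, `CCOc1cccc(C(=O)NCN2CCC(c3cccc[n+]3[O-])CC2)c1`, compound 3 gives 324 nM

Among the three measured compounds, compound 1 has the lowest number in this assay. The nearest to it is compound 2, which sits well beyond the scatter, and compound 3 lies further still; compound 1 therefore stands apart as the compound that needs the least material for its effect in this set. The three differ from one another in several places at once, so no single-point comparison between measured compounds is available.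

Compound 4, `Cc1cccc(NC(=O)CN2CCC(c3ccccc3C)CC2)c1`, keeps the whole of compound 1 except for one group on the shared core: methyl in place of cyano on an aromatic carbon

For the measured compounds named here, no measured pair in this set isolates a change of this kind, so the size of the step has to be estimated rather than read off a neighbour. The change is small in atom count and keeps the substitution place, which argues against a large shift; the loss of the cyano is nonetheless a real change to the group that sits ortho to a large group, and a modest rise in the number, beyond the scatter but not by much, is the expected outcome, which is what a 3.1-fold higher number from compound 1 to compound 4 (0.49 log units; beyond the scatter) expresses. Compound 4 is estimated at 25 nM, with a plausible range from 6 nM to 100 nM.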

Compound 4, half-maximal effective concentration: 340 nM
The estimate for compound 4 lay 14-fold (1.13 log units) below the measured number; the whole stated range lies below it.
By their numbers in this assay, from the lowest: compound 1; then compound 2; then compounds 3 and 4 (each within the scatter of the next).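

In this assay, the aromatic carbon ortho to a large group proves highly sensitive to what it carries: methyl in place of cyano, with the rest of compound 1 kept, gives a 43-fold higher number from compound 1 to compound 4 (1.63 log units; beyond the scatter). The earlier compounds shown here differed in several places at once, so none of the spread among them could be assigned to a single group, whereas this pair shows that one change at this place is enough for a large step. No measured information bears on what lies behind the step, so it stands here only as an observation on this one pair.

Only cyano and methyl are compared at this place, so a chlorine, a methoxy or a plain hydrogen on the same carbon would be needed to show whether the low number of compound 1 is specific to the nitrile or whether the methyl is what raises the number in compound 4. From the compounds shown here alone, whether a step of this size recurs with a different group on the amide nitrogen also remains open.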